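The source may report more compounds than this note shows. Statements on the series, on what has been measured and on what is new or still open speak of the compounds shown alone.

Three measured compounds and one still unmeasured are compared for how strongly they slow the growth of cells in a functional assay on A549 cells (Homo sapiens) for antiproliferative activity, read by MTT assay, with a stated time of 72 h; a lower number here means a stronger inhibitor, a higher number a weaker inhibitor. Compound 1 `CCN(CC)C/C=C/C(=O)Nc1cc2c(N3CCc4ccccc43)ncnc2cc1OC` carries a diethylamino group at the end of its unsaturated amide chain, and in this assay compound 1 gives 1690 nM. Compound 2 `COc1cc2ncnc(N3CCc4ccccc43)c2cc1NC(=O)/C=C/CN1CCCC1` differs from it only by pyrrolidin-1-yl in place of diethylamino on a saturated chain carbon bound to a double-bonded chain carbon; in this assay compound 2 gives 1210 nM, so that change made a 1.4-fold lower number from compound 1 to compound 2 (0.15 log units; within the scatter). Compound 3 `CCN(CC)C/C=C/C(=O)Nc1cc2c(N3CCCc4ccccc43)ncnc2cc1OC` keeps the diethylamino chain of compound 1, but its core is altered by 1,2,3,4-tetrahydroquinolin-1-yl in place of 2,3-dihydro-1H-indol-1-yl on an aromatic carbon; in this assay compound 3 gives 6410 nM, a move of a 3.8-fold higher number from compound 1 to compound 3 (0.58 log units; beyond the scatter), leaving compound 3 with the highest number among the three measured compounds.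

Compound 4 `COc1cc2ncnc(N3CCCc4ccccc43)c2cc1NC(=O)/C=C/CN1CCCC1` joins the core of compound 3 with the amine of compound 2: it differs from compound 3 by pyrrolidin-1-yl in place of diethylamino on a saturated chain carbon bound to a double-bonded chain carbon, the same change that separates compound 1 from compound 2, made at the same place on the chain. Within the data shown here, the only guide to its effect is that single earlier step, which stayed within the usual scatter of repeated measurements. The step from compound 3 to compound 4 is therefore expected to be similarly small, a 1.4-fold lower number from compound 3 to compound 4 (0.14 log units; within the scatter), because the matching earlier change gave a 1.4-fold lower number from compound 1 to compound 2 (0.15 log units; within the scatter). On that basis compound 4 is estimated at 4600 nM in this assay, most likely between 2300 nM and 9500 nM.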

Compound 4, half-maximal inhibitory concentration: 2230 nM
The estimate for compound 4 lay 2.1-fold (0.31 log units) above the measured number; the measured number lies below the stated range.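

In this assay, pyrrolidin-1-yl in place of diethylamino gives a 2.9-fold lower number from compound 3 to compound 4 (0.46 log units; beyond the scatter), and this step cannot be told apart from the same change on the core of compound 1, so on these two cores the change carries over as one effect in the same direction: the same change on two cores in this assay, a 1.4-fold lower number (0.15 log units; within the scatter) from compound 1 to compound 2 and a 2.9-fold lower number (0.46 log units; beyond the scatter) from compound 3 to compound 4, 2.1-fold (0.31 log units) apart, within the scatter of two such steps. The change of ring on the core, read with the pyrrolidin-1-yl chain in place, gives a 1.8-fold higher number from compound 2 to compound 4 (0.27 log units; within the scatter), and it too cannot be told apart from its earlier counterpart on the diethylamino chain: the same change on two cores in this assay, a 3.8-fold higher number (0.58 log units; beyond the scatter) from compound 1 to compound 3 and a 1.8-fold higher number (0.27 log units; within the scatter) from compound 2 to compound 4, 2.1-fold (0.31 log units) apart, within the scatter of two such steps. These pairs do not show that the amine change is really larger on one core than on the other, they do not show that it would carry over to any further core, and they give no reason why the numbers move.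

As far as these compounds go, it remains open whether other amines at the end of the chain, such as dimethylamino, piperidin-1-yl or morpholin-4-yl, would behave alike on both cores. A longer chain carrying the amine is also untested among the compounds shown, so nothing here says how such a change would carry from one core to the other.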